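The compounds below may be only part of what the source reports. "The series", "measured", "known", "first", "only" and "open" are said of these compounds alone.

Compound 2 `C[C@@H](O)CCNC(C)(C)CC(=O)N[C@@H]1CCc2ccccc2N(Cc2ccc(-c3ccccc3-c3nn[nH]n3)cc2)C1=O` is tested in a functional assay (Pituitary gland cell) with Rattus norvegicus as the target (on this read-out higher numbers stand for an effect only at larger amounts of compound and lower numbers for an effect already at smaller amounts), where compound 2 gives 10 nM. Compound 1 `CC(C)(O)CNC(C)(C)CC(=O)N[C@@H]1CCc2ccccc2N(Cc2ccc(-c3ccccc3-c3nn[nH]n3)cc2)C1=O` in this assay gives 10 nM, and the step of no change at the digits printed from compound 1 to compound 2 (within the scatter) shows that exchanging one hydroxyalkyl group for another on the amine nitrogen leaves the read-out where it was. Compound 3 `C[C@@H](O)CCNC(C)(C)C(=O)N[C@@H]1CCc2ccccc2N(Cc2ccc(-c3ccccc3-c3nn[nH]n3)cc2)C1=O` has not yet been tested. It differs from compound 2 by 1-((3-hydroxybutyl)amino)-1-methylethyl in place of 2-((3-hydroxybutyl)amino)-2-methylpropyl on a carbonyl carbon. Among the measured compounds shown here, no measured step alters this part of the molecule: the only known step, from compound 1 to compound 2, changes a group on the amine nitrogen instead and is flat. That step therefore offers little guidance, and shortening the chain that joins the amine to the carbonyl is a different kind of change from swapping a group further out. Compound 3 is expected to show a modest loss in this assay, a step of a 2.5-fold higher number from compound 2 to compound 3 (0.40 log units; beyond the scatter), with an estimated value of 25 nM in a range from 5 nM to 150 nM.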

Compound 3, concentration for half-maximal effect: 100 nM
Beside the measured number, compound 3's estimate is 4.0-fold (0.60 log units) below it; measured number inside the range.
By their numbers in this assay, from the lowest: compounds 1 and 2 (each within the scatter of the next); then compound 3.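

In this assay, the link between the amine and the carbonyl proves far more sensitive than the hydroxyalkyl group further out: the earlier swap on the amine nitrogen was flat, whereas 1-((3-hydroxybutyl)amino)-1-methylethyl in place of 2-((3-hydroxybutyl)amino)-2-methylpropyl gives a 10-fold higher number from compound 2 to compound 3 (1.00 log units; beyond the scatter). A step of the same size appears against the other longer-chain compound, as a 10-fold higher number from compound 1 to compound 3 (1.00 log units; beyond the scatter). No measurement shown here explains this loss.

On these data alone, a still longer chain between the amine and the carbonyl, or a carboxylic acid in place of the hydroxyl group, remains open. As far as these compounds go, it is also open whether the 2-hydroxy-2-methylpropyl group on the amine nitrogen would give the same number as the 3-hydroxybutyl group on the shorter chain.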